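A few compounds are considered here, and "the series" means these few. Any claim that something is new, unique, unknown or untested is made for them only; others in the source may bear on it.

compound 1 `CC1=CC[C@@H]([C@@](C)(O)CCCC(C)(C)NC=S)CC1`: in a functional assay on NCI/ADR cells (Homo sapiens) for cytotoxicity, read by sulforhodamine B assay (on this read-out higher numbers stand for weaker inhibition of growth and lower numbers for stronger inhibition of growth), compound 1 gives only a limit, > 100000 nM.
compound 2 `CC1=CC[C@@H]([C@@](C)(O)CCCC(C)(C)NC(=S)N/N=C\c2ccccc2)CC1`: in this assay compound 2 gives 23800 nM.

Among the compounds with values here, compound 2 holds the only number in this assay. The value of compound 1 is a limit (the limit of > 100000 nM in this assay, at which 1 of the 2 values shown sits). Compound 3 `CC1=CC[C@@H]([C@@](C)(O)CCCC(C)(C)NC(=S)N/N=C\c2ccc(O)cc2)CC1` differs from compound 2 by hydroxy in place of hydrogen on an aromatic carbon. Within the data shown here, the single measured step, an at least 4.2-fold lower number from compound 1 to compound 2 (0.62 log units; beyond the scatter), concerns a different change and offers no guidance on a hydroxy on an aromatic carbon. For compound 3 the expected step is therefore a 1.2-fold lower number from compound 2 to compound 3 (0.08 log units; within the scatter), within the scatter. Compound 3 is estimated at 20000 nM, between 7000 nM and 60000 nM.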

Compound 3, concentration for total growth inhibition: 6070 nM
The estimate for compound 3 lay 3.3-fold (0.52 log units) above the measured number; measured number outside the range, below it.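

In this assay, hydroxy on the aromatic carbon para to a large group gives a 3.9-fold lower number from compound 2 to compound 3 (0.59 log units; beyond the scatter), a modest change toward stronger inhibition of growth. This shows that the aromatic ring present in compound 2 can still be changed with effect at this position, which the step to compound 2 could not show. Nothing shown accounts for the size of this change. As far as these compounds go, whether a methoxy group, an amine or a fluorine atom at the same position would act like hydroxy remains open. So does the effect of hydroxy elsewhere on the ring.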